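This account rests on a few compounds, and the source may have more. Where it says the series, first, only, none or still open, it means among the compounds named here.

Measured to date:
compound 1 `CS(=O)(=O)CCCn1c(Cn2c(=O)n(C3CC3)c3ccncc32)nc2nc(Cl)ccc21` — > 50000 nM (a limit of the assay, not a number)
compound 2 `N#CCCCn1c(Cn2c(=O)n(-c3ncccn3)c3ccncc32)cc2cc(Cl)ccc21` — > 50000 nM (a limit of the assay, not a number)
compound 3 `CS(=O)(=O)CCCn1c(Cn2c(=O)[nH]c3ccncc32)cc2cc(Cl)ccc21` — > 50000 nM (a limit of the assay, not a number)

In an ADME assay on HeLa cells (Homo sapiens) for cytotoxicity, read by ATP content, with a stated time of 3 days (a lower number here means that less compound is tolerated, a higher number that more compound is tolerated), compound 2 gives only a limit, and the same holds for the other two compounds in the series: the limit of > 50000 nM in this assay, at which 3 of the 3 values shown sit. For the measured compounds named here, compound 2 therefore cannot be placed above or below compound 1 or compound 3 on these numbers; all three sit at the same limit, and no measured step between any two of them is available.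

Compound 4 `N#CCCCn1c(Cn2c(=O)n(-c3ccncc3)c3ccncc32)cc2cc(Cl)ccc21` is the next compound to be measured in this assay. It differs from compound 2 in one place: pyridin-4-yl in place of pyrimidin-2-yl on an aromatic nitrogen.

Going by the values given here, with every value so far at the limit, the expected step from compound 2 to compound 4 is a step that the limit leaves unreadable from compound 2 to compound 4, that is, none beyond the scatter. Compound 4 is expected to give 80000 nM in this assay, within a range of 30000 nM to 200000 nM, and most likely to be reported only as a limit once more.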

Compound 4, half-maximal cytotoxic concentration: > 50000 nM
Compound 4: a limit, no number (the forecaster's own chance of this, stated with the estimate: 85%); the middle value is on the limit's open side.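

No step from compound 2 to compound 4 can be read in this assay, since both compounds give only a limit: the limit of > 50000 nM in this assay, at which 4 of the 4 values shown sit.

The compounds shown leave open how far each is tolerated beyond that limit, and whether pyridin-4-yl and pyrimidin-2-yl differ at all here.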